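Pyrimidin-2-yl for dimethylcarbamoyl on the shared core

This account rests on a few compounds, and the source may have more. Where it says the series, first, only, none or still open, it means among the compounds named here.

In an ADME assay on the whole organism (plasma, strain 129/SvEvBrd x C57BL/6) for pharmacokinetics, with Mus musculus as the target, at a dose of 10 mg/kg by the oral route (a higher number here means more compound in the circulation at the dose given, a lower number less compound in the circulation), compound 1 (`CC(=O)c1nc([C@@H](O)[C@H](O)[C@H](O)CO)c(C)[nH]1`) gives 2640 ng.h/mL and compound 2 (`CC(=O)c1nc([C@@H](O)[C@H](O)[C@H](O)CO)c(-c2ccccc2)[nH]1`) gives 3520 ng.h/mL on the shared core. Compound 3 (`CN(C)C(=O)c1nc([C@@H](O)[C@H](O)[C@H](O)CO)c[nH]1`) gives 1740 ng.h/mL in this assay and lies within the scatter of compound 1 but beyond the scatter of compound 2. Compound 4 (`OC[C@@H](O)[C@@H](O)[C@H](O)c1c[nH]c(-c2ncccn2)n1`) has pyrimidin-2-yl in place of dimethylcarbamoyl on an aromatic carbon. Among the measured compounds shown here, the one measured step in a single place (a 1.3-fold higher number from compound 1 to compound 2 (0.12 log units; within the scatter)) is phenyl in place of methyl, a different change, and no measured step covers this one. No step beyond the scatter is expected in this assay for this change. The expected step is a 1.1-fold higher number from compound 3 to compound 4 (0.06 log units; within the scatter) with wide uncertainty. Compound 4 is estimated at 2000 ng.h/mL within a range of 700 ng.h/mL to 5500 ng.h/mL for now.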

Compound 4, area under the concentration-time curve: 799 ng.h/mL
Estimate against measurement, compound 4: 2.5-fold (0.40 log units) above; low and high end bracket the measured number.
By their numbers in this assay, from the lowest: compound 4; then compounds 3, 1 and 2 (each within the scatter of the next, the first and the last beyond it).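

In this assay, the aromatic carbon between two ring nitrogen atoms proves sensitive to the group it carries: pyrimidin-2-yl in place of dimethylcarbamoyl gives a 2.2-fold lower number from compound 3 to compound 4 (0.34 log units; beyond the scatter). Among the compounds shown here, the earlier single-place step, phenyl in place of methyl, stayed within the scatter, so this is the first single-place change to go beyond it. Nothing at hand explains the lower number.

Open, on these data alone, is whether the result reflects the loss of dimethylcarbamoyl or the arrival of pyrimidin-2-yl. As far as these compounds go, how a simple amine or a carboxylic acid on this carbon would read also remains unknown.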